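This account rests on a few compounds, and the source may have more. Where it says the series, first, only, none or still open, it means among the compounds named here.

Compound 3 `CCn1c(SCC(=O)Nc2ccc(C(C)=O)cc2)nnc1-c1ccc(OC)c(OC)c1` gives 69% in a functional assay on the whole organism (strain albino) for inhibition, with Rattus norvegicus as the target, read by paw edema, with stated times of 30 min and 4 h, at a dose of 0.28 mmol/kg by the oral route (a higher number here means more inhibition at the dose given (going by the name of the read-out), a lower number less inhibition), a figure that sits within the scatter of both other measured compounds: compound 1 `C=CCn1c(SCC(=O)Nc2ccc(C(C)=O)cc2)nnc1-c1ccccc1` gives 70%, and compound 2 `CCn1c(SCC(=O)Nc2ccc(/C(C)=N/O)cc2)nnc1-c1ccc(OC)c(OC)c1` gives 75%, where a number 6 percentage points lower from compound 2 to compound 3 (within the scatter). Compound 4 `C=CCn1c(SCC(=O)Nc2ccc(C(C)=O)cc2)nnc1-c1ccc(OC)c(OC)c1` carries the change (vinyl in place of methyl on a saturated chain carbon bound to an aromatic nitrogen). For the measured compounds named here, no measured pair differs in this place alone, so no step bears on it directly. Going by the values given here, the only hint is that compound 1 carries allyl where compound 3 carries ethyl, and the two values stand close, though those compounds differ elsewhere as well. The analyst therefore expects no step beyond the scatter, a number 1 percentage points higher from compound 3 to compound 4 (within the scatter). For compound 4 the analyst estimates 70% in this assay, with a range from 60% to 80%.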

Compound 4, a percentage reported as inhibition, in the whole organism at one dose (the size of the read-out at that dose, not a potency): 70%
Beside the measured number, compound 4's estimate shows no gap at the digits printed; measured number inside the range.
By their numbers in this assay, from the lowest: compounds 3, 1, 4 and 2 (each within the scatter of the next).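

Vinyl in place of methyl on a saturated chain carbon bound to an aromatic nitrogen now has a direct reading, with a number 1 percentage points higher from compound 3 to compound 4 (within the scatter) in this assay for the same shared core. The ethyl to allyl exchange therefore leaves inhibition at this dose within the scatter. With allyl held fixed, 3,4-dimethoxyphenyl in place of phenyl on an aromatic carbon gives no change at the digits printed from compound 1 to compound 4 (within the scatter) as well. No supporting measurement bears on why these steps are so small.

The compounds shown leave open how a longer chain such as butyl, a benzyl group or a chain ending in an amine would read at this place.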